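From Iodo to Benzofuranyl on a Shared Nucleoside Core

The compounds below may be only part of what the source reports. "The series", "measured", "known", "first", "only" and "open" are said of these compounds alone.

Compound 1 `COc1ncnc2c1c(I)cn2[C@@H]1O[C@H](CO)[C@@H](O)[C@H]1O`: > 20000 nM
Compound 2 `CNc1ncnc2c1c(-c1ccccc1)cn2[C@@H]1O[C@H](CO)[C@@H](O)[C@H]1O`: > 20000 nM

In a functional assay on HCT-116 cells (Homo sapiens), read by MTT assay, with a stated time of 72 h (a lower number here means a stronger inhibitor, a higher number a weaker inhibitor), compound 1 gives > 20000 nM, which is a limit of the assay rather than a number. Compound 2 likewise gives only a limit, > 20000 nM. Compound 1 therefore sits at the limit of > 20000 nM in this assay, at which 2 of the 2 values shown sit, with no firm number of its own. Compound 3 `COc1ncnc2c1c(-c1cc3ccccc3o1)cn2[C@@H]1O[C@H](CO)[C@@H](O)[C@H]1O` has not yet been measured; it differs from compound 1 by 1-benzofuran-2-yl in place of iodo on an aromatic carbon. Going by the values given here, no measured step carries this change, so the expected step of a number no higher from compound 1 to compound 3 (the limit leaves the size open) is an estimate only, most likely none beyond the usual scatter. Compound 3 is expected to give about 20000 nM in this assay, within 3000 nM to 60000 nM.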

Compound 3, half-maximal inhibitory concentration: 13800 nM
Beside the measured number, compound 3's estimate is 1.4-fold (0.16 log units) above it; measured number inside the range.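

In this assay, compound 3 gives 13800 nM, so with the larger 1-benzofuran-2-yl on this aromatic carbon the read-out yields a firm number. On these data alone, the change gives an at least 1.4-fold lower number from compound 1 to compound 3 (0.16 log units; that floor lies within the scatter), so no real gain can be claimed, though its true size stays open. Firm numbers remain scarce in this small set: the limit of > 20000 nM in this assay, at which 2 of the 3 values shown sit.

As far as these compounds go, whether an amine or a furan ring on this carbon would move the number beyond the scatter remains open. So does the effect of a carboxylic acid on the 1-benzofuran-2-yl group.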